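A few compounds are considered here, and "the series" means these few. Any claim that something is new, unique, unknown or untested is made for them only; others in the source may bear on it.

In a functional assay (Nicotiana tabacum) (on this read-out higher numbers stand for weaker inhibition and lower numbers for stronger inhibition), compound 1 `CSc1nc(NCC(C)C)c2cccnc2n1`, which carries an isobutyl group on the nitrogen, gives 540 nM. Compound 2 `CSc1nc(Nc2ccccc2)c2cccnc2n1` gives 15900 nM, and compound 3 `CSc1nc(Nc2ccc(F)cc2)c2cccnc2n1` gives 2620 nM, the middle of the three numbers. Compound 4 `CSc1nc(Nc2ccc(Cl)cc2)c2cccnc2n1` is still unmeasured and has chloro in place of fluoro on an aromatic carbon. The closest guide is a 6.1-fold lower number from compound 2 to compound 3 (0.78 log units; beyond the scatter), with fluoro in place of hydrogen on an aromatic carbon. The other step, a 29-fold higher number from compound 1 to compound 2 (1.47 log units; beyond the scatter), comes from a different change, phenyl in place of isobutyl, and says little here. For the measured compounds named here, no measured step exchanges fluoro for chloro, so only a small move towards a lower number is expected in this assay, perhaps no larger than the scatter. The expected step is a 1.7-fold lower number from compound 3 to compound 4 (0.24 log units; within the scatter). Compound 4 is estimated at 1500 nM, with an expected range of 500 nM to 4500 nM.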

Compound 4, half-maximal inhibitory concentration: 8510 nM
Compound 4: middle estimate off by 5.7-fold (0.75 log units), on the low side; measured number above the stated range.
By their numbers in this assay, from the lowest: compound 1; then compound 3; then compounds 4 and 2 (each within the scatter of the next).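

In this assay, this place on the aromatic ring does not treat the two halogens alike: chloro in place of fluoro costs strength (a 3.2-fold higher number from compound 3 to compound 4 (0.51 log units; beyond the scatter)). Chloro in place of hydrogen gives only a small shift within the scatter (a 1.9-fold lower number from compound 2 to compound 4 (0.27 log units; within the scatter)), so the clear gain seen with fluoro does not carry over to chloro. No measurement here explains this difference. Still open, on these data alone, is whether a methoxy group or bromo at this place would behave like fluoro or like chloro.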